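The compounds below may be only part of what the source reports. "The series", "measured", "known", "first", "only" and "open" are said of these compounds alone.

Three quinone-type compounds sharing a tert-butyl-bearing core have been tested in a functional assay on NCI-H460 cells (Homo sapiens) for cytotoxicity, read by MTT assay, with a stated time of 72 h; on this read-out higher numbers stand for weaker inhibition and lower numbers for stronger inhibition. Compound 1 `CCCCNC1=CC(=O)C=C(C(C)(C)C)C1=O` gives 13000 nM in this assay, and compound 2 `CNC1=CC(=O)C=C(C(C)(C)C)C1=O` gives 23000 nM. The change between them, (propyl in place of hydrogen on a saturated chain carbon bound to an amine nitrogen), gave a step of a 1.8-fold lower number from compound 2 to compound 1 (0.25 log units; within the scatter). Compound 3 `CNC1=CC(=O)C(C(C)(C)C)=CC1=O`, in which the same atoms are joined differently, gives 58000 nM in this assay; how its core differs from that of compound 2 is not broken down here. Compound 4 `CCCCNC1=CC(=O)C(C(C)(C)C)=CC1=O` is not yet measured; it differs from compound 3 by propyl in place of hydrogen on a saturated chain carbon bound to an amine nitrogen, the same kind of change as that from compound 2 to compound 1, at the same place. Resting on the step of a 1.8-fold lower number from compound 2 to compound 1 (0.25 log units; within the scatter), he expects a step of a 1.8-fold lower number from compound 3 to compound 4 (0.26 log units; within the scatter), so that compound 4 is estimated to give 32000 nM in this assay, likely between 15000 nM and 70000 nM.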

Compound 4, half-maximal inhibitory concentration: 72000 nM
Compound 4: middle estimate off by 2.3-fold (0.35 log units), on the low side, outside the stated range (above it).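

On the core of compound 3, the change from methylamino to butylamino gave a 1.2-fold higher number from compound 3 to compound 4 (0.09 log units; within the scatter). Set beside the step on the other core, this one does not differ from it by more than repeated measurement allows: the same change on two cores in this assay, a 1.8-fold lower number (0.25 log units; within the scatter) from compound 2 to compound 1 and a 1.2-fold higher number (0.09 log units; within the scatter) from compound 3 to compound 4, 2.2-fold (0.34 log units) apart, within the scatter of two such steps

So the change moved the number little on either core, and these two pairs give no sign that the core alters its outcome; they do not show a real effect that carries over, as neither step stands clear of the scatter.

The compounds shown leave open whether a longer chain than butyl, or a chain ending in a carboxylic acid or an amine, would move the number beyond the scatter on either core. They also leave open whether the result would hold with an isopropyl group in place of tert-butyl.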